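The source may hold more compounds than are shown below. What is called first, only, known or untested is meant among the compounds shown, and "the series" means these compounds.

Compound 1 `COc1cccc(CNCCCNS(=O)(=O)c2cc(C(F)(F)F)cc(C(F)(F)F)c2)c1` was tested in a functional assay on ASPC1 cells (Homo sapiens) for inhibition, read by MTT assay, with a stated time of 72 h (a lower number here means a stronger inhibitor of growth, a higher number a weaker inhibitor of growth), where compound 1 gives 3800 nM. Among the three measured compounds this places compound 1 second highest: its nearest neighbour is compound 2 `O=S(=O)(NCCCNCC1COc2ccccc2O1)c1cc(C(F)(F)F)cc(C(F)(F)F)c1`, which in this assay gives 2900 nM, and the step of a 1.3-fold lower number from compound 1 to compound 2 (0.12 log units; within the scatter) stays within the scatter. Furthest away lies compound 3 `O=S(=O)(NCCNCc1cccc2ccccc12)c1cc(C(F)(F)F)cc(C(F)(F)F)c1`, which in this assay gives 22000 nM, a higher number than that of compound 1; since compound 3 differs from compound 1 in more than one place, only the two values themselves are to be read there.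

Compound 4 `O=S(=O)(NCCCNCc1ccc(Cl)c(Cl)c1)c1cc(C(F)(F)F)cc(C(F)(F)F)c1` is not yet measured. It differs from compound 1 as follows: 3,4-dichlorophenyl in place of 3-methoxyphenyl on a saturated chain carbon bound to an amine nitrogen. For the measured compounds named here, the only measured step that bears on this is the exchange of the aryl group at the same place, from compound 1 to compound 2, which was within the scatter. Going by the values given here, no measured pair shows the present exchange itself, so no step beyond the scatter is expected. The estimate for compound 4 in this assay is 3000 nM, with a range from 1200 nM to 9000 nM, meaning an expected step of a 1.3-fold lower number from compound 1 to compound 4 (0.10 log units; within the scatter).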

Compound 4, concentration for 50% growth inhibition: 2800 nM
Compound 4: the middle estimate sits 1.1-fold (0.03 log units) above what was measured; measured number inside the range.
By their numbers in this assay, from the lowest: compounds 4, 2 and 1 (each within the scatter of the next); then compound 3.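

In this assay, 3,4-dichlorophenyl in place of 3-methoxyphenyl on a saturated chain carbon bound to an amine nitrogen gives a 1.4-fold lower number from compound 1 to compound 4 (0.13 log units; within the scatter), so exchanging a substituted phenyl group for another at this place, with the methoxy oxygen gone and two chlorine atoms present, leaves the read-out unchanged within the scatter. The exchange of 2,3-dihydro-1,4-benzodioxin-2-yl for 3,4-dichlorophenyl gives a 1.0-fold lower number from compound 2 to compound 4 (0.02 log units; within the scatter), so all three groups at this place, in compound 1, compound 2 and compound 4, now cannot be told apart in this assay. No available evidence bears on why these values agree.

From the compounds shown here alone, whether this holds for a phenyl ring carrying a carboxylic acid or an amine remains open. Compound 3 also leaves open what a longer chain would do, since it differs from the others in more than one place.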